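Butyl to ethynyl on the aromatic carbon of compound 2

The source may hold more compounds than are shown below. What is called first, only, known or untested is meant among the compounds shown, and "the series" means these compounds.

Compound 1 `CCCCNc1nc(N)nc(C)c1CCCC(C)(C)O` gives 1220 nM in an assay on HEK293 cells for agonist activity at Toll-like receptor 8 (Homo sapiens), read by spectrophotometry; a lower number here means that less compound is needed, a higher number that more compound is needed for the effect.
Compound 2 `CCCCNc1nc(N)nc(C)c1CCCC` gives 780 nM in this assay.
Compound 3 `CCCCNc1nc(N)nc(C)c1CCCc1ccccc1` gives 749 nM in this assay.

Among these three numbers compound 2 stands second highest; its nearest neighbour is compound 3 and the furthest is compound 1, and every gap between them sits within the scatter. The unmeasured compound 4 `C#Cc1c(C)nc(N)nc1NCCCC` differs from compound 2 in one place: ethynyl in place of butyl on an aromatic carbon.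

The measured steps are a 1.6-fold lower number from compound 1 to compound 2 (0.19 log units; within the scatter), a 1.6-fold lower number from compound 1 to compound 3 (0.21 log units; within the scatter) and a 1.0-fold lower number from compound 2 to compound 3 (0.02 log units; within the scatter). All three change only the end of the three-carbon chain hanging from the shared core, and none of them moves the number beyond the scatter. For the measured compounds named here, none of them touches the aromatic carbon where butyl gives way to ethynyl, so no measured step bears directly on the change to compound 4; the data only show that the chain end tolerates swapping without a clear effect.

With nothing to point one way or the other, compound 4 is expected to land near compound 2 in this assay, with a wide range, as a 1.9-fold higher number from compound 2 to compound 4 (0.28 log units; within the scatter). The estimate for compound 4 is 1500 nM, expected between 300 nM and 8000 nM.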

Compound 4, half-maximal effective concentration: 4900 nM
Beside the measured number, compound 4's estimate is 3.3-fold (0.51 log units) below it; low and high end bracket the measured number.
By their numbers in this assay, from the lowest: compounds 3, 2 and 1 (each within the scatter of the next); then compound 4.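

In this assay, putting ethynyl in place of butyl on the aromatic carbon gives a 6.3-fold higher number from compound 2 to compound 4 (0.80 log units; beyond the scatter) and is the only step among the compounds shown that lies beyond the scatter. Swapping groups at the chain end in compounds 1, 2 and 3 moved the number by no more than the scatter, whereas this aromatic carbon, ortho to a butylamino group and ortho to a methyl group, does respond to a change of group: here, more compound is needed for the same effect once the four-carbon butyl gives way to ethynyl, with its triple bond. Nothing measured here says why the number rises.

The compounds shown leave open whether the rise goes with the shorter group or with the triple bond, and an ethyl group on this carbon would help to tell those two apart. They also leave open how this position responds to groups of other kinds, such as a nitrile or an amine, or to a longer chain ending in a triple bond.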